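A few compounds are considered here, and "the series" means these few. Any claim that something is new, unique, unknown or untested is made for them only; others in the source may bear on it.

Measured compounds in the series:
compound 1 `COc1ncc(-c2ccc3c(c2)N(c2ccc(C)cc2)C(=O)CO3)cc1NS(=O)(=O)c1ccc(F)cc1` — 22700 nM
compound 2 `Cc1ccc(N2C(=O)COc3ccc(-c4cnc(Cl)c(NS(=O)(=O)c5ccc(F)cc5)c4)cc32)cc1` — 34300 nM
compound 3 `O=C1COc2ccc(-c3cccc(NS(=O)(=O)c4ccc(F)cc4)c3)cc2N1C1CCCCC1` — 18300 nM

In a functional assay on HCT-116 cells (Homo sapiens) for antiproliferative activity, read by MTT assay, with a stated time of 72 h (a lower number here means a stronger inhibitor, a higher number a weaker inhibitor), compound 1 gives 22700 nM. The three measured numbers do not separate: the step of a 1.5-fold higher number from compound 1 to compound 2 (0.18 log units; within the scatter) is within the scatter, and compound 3, with 18300 nM, also lies within the scatter of compound 1. Compound 1 therefore stands among three numbers that are indistinguishable in this assay, all weak.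

Compound 4 `COc1ncc(-c2ccc3c(c2)N(C(C)C)C(=O)CO3)cc1NS(=O)(=O)c1ccc(F)cc1` differs from compound 1 in one place: isopropyl in place of 4-methylphenyl on an amide-type nitrogen in a ring. Among the compounds with values here, none of the measured steps touches this position. Within the data shown here, the only single-point step, a 1.5-fold higher number from compound 1 to compound 2 (0.18 log units; within the scatter), concerns the group on the aromatic carbon and says nothing about the amide-type nitrogen. Compound 3 carries a saturated ring on that nitrogen and shows a number within the scatter of compound 1, but it also differs elsewhere, so it is not a clean comparison. What the data do show is that every change tried so far left the number within the scatter.

On that basis no step beyond the scatter is expected for compound 4; the estimate is 25000 nM, a step of a 1.1-fold higher number from compound 1 to compound 4 (0.04 log units; within the scatter), with a range from 8000 nM to 80000 nM.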

Compound 4, half-maximal inhibitory concentration: 19200 nM
The estimate for compound 4 lay 1.3-fold (0.11 log units) above the measured number; the measured number falls inside the stated range.
By their numbers in this assay, from the lowest: compounds 3, 4, 1 and 2 (each within the scatter of the next).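

In this assay, within the data shown here, the step of a 1.2-fold lower number from compound 1 to compound 4 (0.07 log units; within the scatter) gives the first single-point reading at the amide-type nitrogen in a ring, for isopropyl in place of 4-methylphenyl. On this nitrogen, the change from a group of 7 heavy atoms with a six-membered aromatic ring of carbon only to a group of 3 heavy atoms with no ring leaves the number within the scatter, so this aromatic ring is not needed to keep the number of compound 1 in this assay. No supporting data bear on why the two groups read alike.

The compounds shown leave open whether a group of another kind on this nitrogen, such as a chain ending in an amine or in a carboxylic acid, would give a step beyond the scatter. Also open, as far as these compounds go, is whether isopropyl would read the same in compound 2, with chloro in place of methoxy on the aromatic carbon.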